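Notes on the series: from compound 3 to compound 4

This account rests on a few compounds, and the source may have more. Where it says the series, first, only, none or still open, it means among the compounds named here.

Measured in a functional assay on KARPAS-422 cells (Homo sapiens) for antiproliferative activity, read by resazurin assay, with a stated time of 72 h; on this read-out higher numbers stand for weaker inhibition and lower numbers for stronger inhibition:
- compound 1 `Cc1cc(C)c(CN2CCc3c(Cl)cc([C@H](CO)[C@H]4CCCO4)c(Cl)c3C2=O)c(=O)[nH]1`: 63 nM
- compound 2 `COC(c1cc(Cl)c2c(c1Cl)C(=O)N(Cc1c(C)cc(C)[nH]c1=O)CC2)C1CCS(=O)(=O)CC1`: 970 nM; 24 nM (2 entries)
- compound 3 `Cc1cc(C)c(CN2CCc3c(Cl)cc([C@H](CO)[C@@H]4CCCO4)c(Cl)c3C2=O)c(=O)[nH]1`: 57 nM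

Compound 3 gives 57 nM and stands level with compound 1 at 63 nM, the pair being separated by a 1.1-fold lower number from compound 1 to compound 3 (0.04 log units; within the scatter) and no more. Compound 2 offers no single number for comparison, its record being the several entries of compound 2 in this assay, 970 nM; 24 nM (2 entries) in this assay.

Compound 4 `Cc1cc(C)c(CN2CCc3c(Cl)cc([C@@H](CO)[C@@H]4CCOC4)c(Cl)c3C2=O)c(=O)[nH]1` has the same atoms as compound 3, joined differently: a group of 8 heavy atoms (6 carbon, 2 oxygen; one five-membered non-aromatic ring with 1 hetero atom) in place of a group of 8 heavy atoms (6 carbon, 2 oxygen; one five-membered non-aromatic ring with 1 hetero atom), on an aromatic carbon on an aromatic carbon, ortho to a chloro group.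

Within the data shown here, the only measured step between close neighbours is the small one from compound 1 to compound 3, and it concerns the fact that compounds 1 and 3 differ only in the configuration as drawn only. Among the measured compounds shown here, no measured step covers a group joined differently, so its size and direction remain open. A modest move towards a higher number is assumed, with a wide margin.

Expected on this basis is a 1.8-fold higher number from compound 3 to compound 4 (0.24 log units; within the scatter) in this assay.

For compound 4 the estimated value is 100 nM, with an expected range from 25 nM to 400 nM.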

Compound 4, half-maximal inhibitory concentration: 3950 nM
Estimate against measurement, compound 4: 40-fold (1.60 log units) below; measured number outside the range, above it.
By their numbers in this assay, from the lowest: compounds 3 and 1 (each within the scatter of the next); then compound 4.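

At the aromatic carbon ortho to a chloro group, how the group's atoms are joined matters a great deal: in this assay the rejoined group gives a 69-fold higher number from compound 3 to compound 4 (1.84 log units; beyond the scatter) and a 63-fold higher number from compound 1 to compound 4 (1.80 log units; beyond the scatter), although its ring size, hetero atom count and hydrogen-bond donor and acceptor counts stay the same. Among these compounds, the earlier compounds showed only a change of configuration at a saturated ring carbon, and that step, a 1.1-fold lower number from compound 1 to compound 3 (0.04 log units; within the scatter), lies within the scatter, so this is the first sign of a strong response at this position. Nothing in the data accounts for the size of the new step.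

On these data alone, whether another configuration of the group in compound 4 would give a lower number stays open, as does the effect of an amine or a carboxylic acid in this group. The standing of compound 2 is also unsettled by its split record: the several entries of compound 2 in this assay, 970 nM; 24 nM (2 entries)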